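An Amino Acid Step from a Methylsulfonyl Acid

This account rests on a few compounds, and the source may have more. Where it says the series, first, only, none or still open, it means among the compounds named here.

Compound 2 `CCNC(=O)Nc1nc2cc(-c3cnc(N4CCC(C(=O)O)(S(C)(=O)=O)CC4)nc3)cc(-c3ccccn3)c2s1` carries a methylsulfonyl group on a saturated ring carbon of a shared core that it has in common with compound 1 `CCNC(=O)Nc1nc2cc(-c3cnc(N4CCC(C(=O)O)CC4)nc3)cc(-c3ccccn3)c2s1`. In a physicochemical assay for solubility, read by turbidimetry, in phosphate buffer, with a stated time of 24 h, at pH 7.4 (a higher number here means a more soluble compound, a lower number a less soluble compound), compound 2 gives > 800 ug/mL, which is a limit of the assay rather than a number. Compound 1 likewise reaches > 800 ug/mL in this assay, again a limit. The step that the two limits leave unreadable from compound 1 to compound 2 therefore cannot be read, and the evidence on the measured compounds ends at the limit of > 800 ug/mL in this assay, at which 2 of the 2 values shown sit. Compound 3 `CCNC(=O)Nc1nc2cc(-c3cnc(N4CCC(N)(C(=O)O)CC4)nc3)cc(-c3ccccn3)c2s1` differs from compound 2 by amino in place of methylsulfonyl on a saturated ring carbon. Among the compounds with values here, only the step from compound 1 to compound 2 touches the same saturated ring carbon, and its size is hidden by the limit; no measured step gives a direction or a size for the change to compound 3. Compound 3 is expected to sit at or beyond the same limit, with the step that the limit leaves unreadable from compound 2 to compound 3 expected to be unreadable in the same way. The estimate for compound 3 in this assay is 1000 ug/mL, expected to lie between 400 ug/mL and 2500 ug/mL.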

Compound 3, solubility: 25 ug/mL
Beside the measured number, compound 3's estimate is 40-fold (1.60 log units) above it, and the stated range ends above it.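

At this saturated ring carbon, three ring bonds from the ring nitrogen, the choice of group makes a large difference in this assay: amino in place of methylsulfonyl gives an at least 32-fold lower number from compound 2 to compound 3 (1.50 log units; beyond the scatter), and amino in place of hydrogen gives an at least 32-fold lower number from compound 1 to compound 3 (1.50 log units; beyond the scatter). Compound 3 is therefore the first compound shown with a readable number, and it sits lowest of the three, whereas hydrogen and methylsulfonyl on the same carbon could not be told apart in this read-out. Both new steps are only lower bounds and the step between the two earlier compounds cannot be read, since their values are limits and not numbers: the limit of > 800 ug/mL in this assay, at which 2 of the 3 values shown sit.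

From the compounds shown here alone, how far compound 1 and compound 2 truly lie above compound 3 remains open, and with it the full size of both steps and any order between hydrogen and methylsulfonyl. Also open, going by these compounds, is whether a methyl, a hydroxyl or an acetylated amino on the same ring carbon would stay at the limit or fall as amino does, and so whether this drop belongs to amino alone or to a wider set of groups.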